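Bromo to Methoxy on the Aryl Ring of Compound 2

A few compounds are considered here, and "the series" means these few. Any claim that something is new, unique, unknown or untested is made for them only; others in the source may bear on it.

Three compounds share one core: compound 1 `CC1(C)Cc2c(OCc3ccccc3)ccc(C(=O)/C=C/c3cn(-c4ccccc4)nc3-c3ccc([N+](=O)[O-])cc3)c2O1`, compound 2 `CC1(C)Cc2c(OCc3ccccc3)ccc(C(=O)/C=C/c3ccc(Br)cc3)c2O1` and compound 3 `CC1(C)Cc2c(ccc(C(=O)/C=C/c3cn(-c4ccccc4)nc3-c3cccc([N+](=O)[O-])c3)c2OCc2ccccc2)O1`. All were tested in a functional assay on PC-3 cells (Homo sapiens) for antiproliferative activity, read by MTT assay, with a stated time of 48 h; a lower number here means a stronger inhibitor, a higher number a weaker inhibitor. For compound 1 the result is only a limit of the assay, > 100000 nM. For compound 3 the result is likewise only a limit, > 100000 nM. Compound 2 too gives only a limit, > 100000 nM. Where compound 2 stands on the numbers shown is therefore simple: it sits at the limit, as do the other two (the limit of > 100000 nM in this assay, at which 3 of the 3 values shown sit).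

Compound 4 `COc1ccc(/C=C/C(=O)c2ccc(OCc3ccccc3)c3c2OC(C)(C)C3)cc1` is the unmeasured partner of compound 2, and the change between them is methoxy in place of bromo on an aromatic carbon. Among the measured compounds shown here, no step between measured compounds is at hand, so the expected size rests on compound 2 alone; the reasonable expectation is no shift beyond the scatter in this assay. Compound 4 is thus estimated in this assay at 100000 nM, with a range from 30000 nM to 300000 nM. The estimate implies a number no higher from compound 2 to compound 4 (the limit leaves the size open), and most likely the assay again reports only a limit.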

Compound 4, half-maximal inhibitory concentration: 13500 nM
The estimate for compound 4 lay 7.4-fold (0.87 log units) above the measured number; measured number below the stated range.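

At this position, para to a large group, methoxy in place of bromo is the first change shown to move the result in this assay, giving an at least 7.4-fold lower number from compound 2 to compound 4 (0.86 log units; beyond the scatter). The size of this step is only a floor, as compound 2 gives a limit rather than a number, so the true gap could be larger. Compound 4 thus shows that a compound with this core and this aryl side can give a measurable number, which none of the earlier compounds did: the limit of > 100000 nM in this assay, at which 3 of the 4 values shown sit.

From the compounds shown here alone, whether the drop belongs to methoxy in particular or would follow other replacements of bromo stays open, and an amine, a hydroxy group or a longer ethoxy chain at the same place would bear on that. The compounds shown also say nothing about why the number falls, or whether the same change would act alike on the other aryl groups.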